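A few compounds are considered here, and "the series" means these few. Any claim that something is new, unique, unknown or untested is made for them only; others in the source may bear on it.

Compound 1 `CNC(=O)[C@@]12C[C@@H]1[C@@H](n1cnc3c(NC)nc(C#Cc4ccccc4OC)nc31)[C@H](O)[C@@H]2O`: 0.77 nM
Compound 2 `CNC(=O)[C@@]12C[C@@H]1[C@@H](n1cnc3c(NC)nc(C#Cc4ccc(OC)cc4)nc31)[C@H](O)[C@@H]2O`: 0.63 nM
Compound 3 `CNC(=O)[C@@]12C[C@@H]1[C@@H](n1cnc3c(NC)nc(C#Cc4cccnc4)nc31)[C@H](O)[C@@H]2O`: 2.15 nM

The three compounds share one core and differ only in the aromatic group that sits on the triple-bonded carbon. In an assay on CHO cells for displacement of a labelled ligand from adenosine receptor A3 (Homo sapiens), read by scintillation counting, with a stated time of 60 min (a lower number here means a stronger inhibitor, a higher number a weaker inhibitor), compound 3 gives the highest of the three numbers, at 2.15 nM. The steps of a 2.8-fold higher number from compound 1 to compound 3 (0.45 log units; beyond the scatter) and a 3.4-fold higher number from compound 2 to compound 3 (0.53 log units; beyond the scatter) are both beyond the scatter and modest in size, whereas a 1.2-fold lower number from compound 1 to compound 2 (0.09 log units; within the scatter) lies within the scatter. Compound 4 `CNC(=O)[C@@]12C[C@@H]1[C@@H](n1cnc3c(NC)nc(C#Cc4ncccn4)nc31)[C@H](O)[C@@H]2O` is built from compound 3 by the change (pyrimidin-2-yl in place of pyridin-3-yl on a triple-bonded carbon). Among the compounds with values here, no measured step exchanges one nitrogen-bearing ring for another on this carbon, so the only guides are the two steps in which a methoxyphenyl gave way to pyridin-3-yl, each a modest rise in the number. On that footing a further modest rise, or no step beyond the scatter, is expected for a 1.9-fold higher number from compound 3 to compound 4 (0.27 log units; within the scatter), with the second nitrogen in the ring counted as the only new feature. Compound 4 is therefore estimated at 4 nM, within a range from 1.5 nM to 12 nM in this assay.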

Compound 4, inhibition constant: 1.97 nM
Estimate against measurement, compound 4: 2.0-fold (0.31 log units) above; measured number inside the range.
By their numbers in this assay, from the lowest: compounds 2 and 1 (each within the scatter of the next); then compounds 4 and 3 (each within the scatter of the next).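

In this assay, within the data shown here, pyrimidin-2-yl in place of pyridin-3-yl on a triple-bonded carbon gives a 1.1-fold lower number from compound 3 to compound 4 (0.04 log units; within the scatter), so going from 1 ring hetero atom to 2 leaves the number within the scatter, and the further rise seen as possible from the earlier steps does not appear. Among these compounds, the methoxyphenyl compounds stay apart from the new compound, with a 3.1-fold higher number from compound 2 to compound 4 (0.50 log units; beyond the scatter) and a 2.6-fold higher number from compound 1 to compound 4 (0.41 log units; beyond the scatter), both modest and beyond the scatter, so the separation first seen with pyridin-3-yl holds for a second nitrogen-bearing ring, with no compound among the four going against it. Nothing on hand explains why these two rings give numbers within the scatter of each other.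

The two nitrogen-bearing rings differ both in their count of ring nitrogens and in where those nitrogens stand, so the compounds shown cannot separate these two differences, and a pyridin-2-yl ring would bear on that question. As far as these compounds go, it also remains open whether an unsubstituted phenyl would fall with the methoxyphenyl compounds or with the nitrogen-bearing rings, and how a saturated ring such as cyclohexyl or a phenyl carrying a carboxylic acid would fare on this carbon.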